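Compound 4: a step down expected from compound 3

The source may hold more compounds than are shown below. What is called first, only, known or untested is meant among the compounds shown, and "the series" means these compounds.

In a toxicity assay on microsomes from liver (Homo sapiens) for metabolic stability, read by LC-MS, using NADPH, tested at 1 uM (a higher number here means faster removal of the compound, a lower number slower removal), compound 3 `Cc1nc(C)n(CC(=O)N2CCN(c3sc(C(F)(F)F)nc3-c3cnc(N4CCCC4)nc3)C[C@H]2C)n1` stands highest at 338 mL.min-1.g-1 and compound 1 `Cc1nc(C)n(CC(=O)N2CCN(c3sc(C(F)(F)F)nc3-c3cnc(OC4CCC4)nc3)C[C@H]2C)n1` is nearest at 51 mL.min-1.g-1 in this series. Compound 2 `Cc1ncc(-c2nc(C(F)(F)F)sc2N2CCN(C(=O)Cn3nc(C)nc3C)[C@H](C)C2)cn1` gives < 10 mL.min-1.g-1, which is a limit of the assay. Compound 4 `COc1ccc(-c2nc(C(F)(F)F)sc2N2CCN(C(=O)Cn3nc(C)nc3C)[C@H](C)C2)cn1` carries 6-methoxypyridin-3-yl in place of 2-(pyrrolidin-1-yl)pyrimidin-5-yl on an aromatic carbon. Going by the values given here, two measured steps bear most directly on this change, and both introduce pyrrolidin-1-yl: a 6.6-fold higher number from compound 1 to compound 3 (0.82 log units; beyond the scatter) and an at least 33-fold higher number from compound 2 to compound 3 (1.52 log units; beyond the scatter). Between the two compounds without it, the step is an at least 5.1-fold lower number from compound 1 to compound 2 (0.70 log units; beyond the scatter). Compound 4 also lacks pyrrolidin-1-yl, and its methoxy group resembles the cyclobutyloxy of compound 1 more than the methyl of compound 2, so a fall of about the size of a 6.6-fold higher number from compound 1 to compound 3 (0.82 log units; beyond the scatter) is expected in reverse. Among the compounds with values here, no measured step isolates the change of aromatic ring, which widens the range. The expected step is an 8.5-fold lower number from compound 3 to compound 4 (0.93 log units; beyond the scatter), towards a lower number and beyond the scatter. For compound 4 the estimate is 40 mL.min-1.g-1, with an expected range from 15 mL.min-1.g-1 to 110 mL.min-1.g-1.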

Compound 4, intrinsic clearance in microsomes: < 10 mL.min-1.g-1
Compound 4: no number, only a limit; the forecaster's own chance of this, stated with the estimate: 10%; middle value at least 4.0-fold (0.60 log units) away from the limit.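

In this assay, 6-methoxypyridin-3-yl at this aromatic carbon gives an at least 33-fold lower number from compound 3 to compound 4 (1.52 log units; beyond the scatter) and an at least 5.1-fold lower number from compound 1 to compound 4 (0.70 log units; beyond the scatter). Going by these compounds alone, an alkoxy group on the aromatic ring at this position therefore does not by itself go with the higher number of compound 1, and 2-methylpyrimidin-5-yl is no longer the only group here to reach the limit. The value of compound 4 is a limit and not a number: the limit of < 10 mL.min-1.g-1 in this assay, at which 2 of the 4 values shown sit.

The step from compound 2 to compound 4 cannot be read, as both values are limits, and neither compound shows how far below the limit it might lie. Within the data shown here, no pair separates the size of the alkoxy group from the change of aromatic ring, so 2-methoxypyrimidin-5-yl or 6-(cyclobutyloxy)pyridin-3-yl would be the informative groups at this position.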